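Chloro added to the benzamide of compound 2

The compounds below may be only part of what the source reports. "The series", "measured", "known", "first", "only" and "open" are said of these compounds alone.

Measured so far:
compound 2, `O=C(CSc1nc2ccc(NC(=O)c3ccccc3)cc2s1)NCc1ccccc1`: 35600 nM
compound 1, `COc1ccc(CNC(=O)CSc2nc3ccc(NC(=O)c4ccc(Cl)cc4)cc3s2)cc1`: 19200 nM

In a functional assay on MCF7 cells (Homo sapiens) for cytotoxicity, read by MTT assay, with a stated time of 48 h (a higher number here means a weaker inhibitor, a lower number a stronger inhibitor), compound 2 gives 35600 nM, the highest of the two numbers available. Its nearest neighbour is compound 1, `COc1ccc(CNC(=O)CSc2nc3ccc(NC(=O)c4ccc(Cl)cc4)cc3s2)cc1`, which in this assay gives 19200 nM; the two differ from compound 2 in two places at once, and the gap between them lies within the scatter, so no order can be read from it.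

Compound 3, `O=C(CSc1nc2ccc(NC(=O)c3ccc(Cl)cc3)cc2s1)NCc1ccccc1`, differs from compound 2 in one place: chloro in place of hydrogen on an aromatic carbon. Going by the values given here, nothing measured isolates this single change; the only comparison on hand (compound 1 against compound 2) is confounded by a second change and is itself within the scatter. The expected step is therefore small, toward a somewhat lower number if anything, and not clearly beyond the scatter: a 1.4-fold lower number from compound 2 to compound 3 (0.15 log units; within the scatter). For compound 3 the estimate in this assay is 25000 nM, expected to fall between 10000 nM and 60000 nM.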

Compound 3, half-maximal inhibitory concentration: 25900 nM
Estimate against measurement, compound 3: 1.0-fold (0.02 log units) below; the measured number falls inside the stated range.
By their numbers in this assay, from the lowest: compounds 1, 3 and 2 (each within the scatter of the next).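

In this assay, chloro in place of hydrogen on the benzamido group, para to a large group, can now be read as a single change: a 1.4-fold lower number from compound 2 to compound 3 (0.14 log units; within the scatter). Going by these compounds alone, the methoxy group of compound 1 is also isolated as a single change for the first time: a 1.3-fold higher number from compound 1 to compound 3 (0.13 log units; within the scatter). Both steps stay within the scatter, so neither change separates the compounds it links, and no supporting evidence bears on either step.

As far as these compounds go, it remains open whether an amine or a carboxylic acid at the place taken by chloro, or a longer chain in place of the benzyl group, would give a step beyond the scatter. Also open, from the compounds shown here alone, is whether these steps would hold outside this assay, the only read-out available for the three compounds.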